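The source may report more compounds than this note shows. Statements on the series, on what has been measured and on what is new or still open speak of the compounds shown alone.

Within the data shown here, in an ADME assay on L929 cells (Mus musculus, culture collection number NCTC 929) for cytotoxicity, read by MTT assay, with a stated time of 72 h (a higher number here means a weaker inhibitor, a lower number a stronger inhibitor), compound 2 (`CCCCCCCCCCCCCCCCc1c(O)cc(C)oc1=O`) gives 38200 nM, the lower of the two numbers so far, while compound 1 (`CCCCCCCCc1c(O)cc(C)oc1=O`) gives 145000 nM. Compound 3 (`CCCCCCCCCCc1c(O)cc(C)oc1=O`) differs from compound 2 by hydrogen in place of hexyl on a saturated chain carbon, ten or more bonds along the chain from an aromatic carbon. Among the measured compounds shown here, this takes back part of the chain extension seen in the only measured step, a 3.8-fold lower number from compound 1 to compound 2 (0.58 log units; beyond the scatter), which placed octyl in place of hydrogen on a saturated chain carbon, eight bonds along the chain from an aromatic carbon. The chain of compound 3 is shorter than that of compound 2 but longer than that of compound 1, so its number is expected to fall between theirs. One step cannot show whether the change is spread evenly along the chain, so the range stays wide. The expected shift in this assay is a 2.5-fold higher number from compound 2 to compound 3 (0.40 log units; beyond the scatter), towards a higher number and smaller than the measured step. For compound 3 the estimated value is 95000 nM, with an expected range of 45000 nM to 190000 nM.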

Compound 3, half-maximal inhibitory concentration: 56000 nM
Compound 3: middle estimate off by 1.7-fold (0.23 log units), on the high side; the measured number falls inside the stated range.
By their numbers in this assay, from the lowest: compounds 2 and 3 (each within the scatter of the next); then compound 1.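

Notes on the series: in this assay, the ethyl addition already gives a step beyond the scatter (a 2.6-fold lower number from compound 1 to compound 3 (0.41 log units; beyond the scatter)). Hexyl does not separate the two longer-chain compounds (a 1.5-fold higher number from compound 2 to compound 3 (0.17 log units; within the scatter)), so compound 2 and compound 3 cannot be told apart here, something the single earlier step, with octyl entering as one piece, could not show. Across these three compounds, the readable step therefore lies with the ethyl addition, and no measurement bears on why this is so.

Still open, from the compounds shown here alone, is whether a longer chain than that of compound 2, or a chain shorter than that of compound 1, would give a step beyond the scatter in this assay. Also open, going by these compounds, is whether the step depends on an unbroken hydrocarbon chain, which could be tested by placing an amine or a carboxylic acid at the end of the chain on the shared core.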